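Chromenone hydrazones: adding a second benzyloxy group

The source may report more compounds than this note shows. Statements on the series, on what has been measured and on what is new or still open speak of the compounds shown alone.

Measured compounds:
compound 1 `O=c1cc(/C=N\O)c2c(OCc3ccccc3)cc(OCc3ccccc3)cc2o1` 38700 nM
compound 2 `O=c1cc(/C=N\Nc2ccc([N+](=O)[O-])cc2)c2ccc(OCc3ccccc3)cc2o1` 9510 nM

Compound 2 gives the lower of the two numbers in a functional assay, read by spectrophotometry, with a stated time of 3 min; on this read-out lower numbers stand for stronger inhibition and higher numbers for weaker inhibition; compound 1 sits at a higher number, and the gap between them lies beyond the scatter. Compound 3 `O=c1cc(/C=N\Nc2ccc([N+](=O)[O-])cc2)c2c(OCc3ccccc3)cc(OCc3ccccc3)cc2o1` follows from compound 2 by benzyloxy in place of hydrogen on an aromatic carbon. Among the measured compounds shown here, no pair of measured compounds shows this change alone, so its effect is not known here. The step of a 1.2-fold lower number from compound 2 to compound 3 (0.08 log units; within the scatter) is expected to be small, within the scatter, in either direction. Compound 3 is therefore estimated at 8000 nM, with a range from 3000 nM to 25000 nM.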

Compound 3, half-maximal inhibitory concentration: 15500 nM
For compound 3 the middle estimate is 1.9-fold (0.29 log units) below the measured one; the measured number falls inside the stated range.
By their numbers in this assay, from the lowest: compounds 2 and 3 (each within the scatter of the next); then compound 1.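

In this assay, benzyloxy in place of hydrogen on an aromatic carbon ortho to a fused ring gives a 1.6-fold higher number from compound 2 to compound 3 (0.21 log units; within the scatter) and so shows that this second benzyloxy group leaves the read-out within the scatter. Among the compounds shown here, with both benzyloxy groups present, (4-nitrophenyl)amino in place of hydroxy on a double-bonded nitrogen gives a 2.5-fold lower number from compound 1 to compound 3 (0.40 log units; beyond the scatter) as the first single-place step beyond the scatter. No measurement here explains either step. Going by these compounds, whether methoxy, hydroxy or an amine at this aromatic carbon would also stay within the scatter remains open. So does how an unsubstituted phenylamino group on that nitrogen would compare.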